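The source may hold more compounds than are shown below. What is called first, only, known or untested is meant among the compounds shown, and "the series" means these compounds.

In a functional assay on DU-145 cells (Homo sapiens) for inhibition, read by trypan blue exclusion, with a stated time of 96 h (a higher number here means a weaker inhibitor of growth, a lower number a stronger inhibitor of growth), compound 1 (`O=C(/C(=C\c1ccc([N+](=O)[O-])c(O)c1)SCc1ccc(Br)cc1)c1ccc(C(F)(F)F)cc1`) gives 1000 nM, and compound 2 (`O=C(/C(=C\c1ccc(OCc2ccccc2)cc1)S(=O)(=O)Cc1ccc(Cl)cc1)c1ccc(Cl)cc1`) gives 1000 nM, so the two stand level and neither can be ranked above the other. Compound 3 (`O=C(/C(=C\c1ccc([N+](=O)[O-])c(O)c1)SCc1ccc(Br)cc1)C1CCNC1`) keeps the core of compound 1 but carries pyrrolidin-3-yl in place of 4-(trifluoromethyl)phenyl on a carbonyl carbon. Among the compounds with values here, no measured pair shows what such an exchange does, and the two compounds in hand differ in several places at once. The expectation therefore starts from compound 1 at 1000 nM and remains tentative. A moderate loss of growth inhibition is expected in this assay, which would appear as a higher number. The estimated change is a 2.5-fold higher number from compound 1 to compound 3 (0.40 log units; beyond the scatter), and it may not lie far beyond the usual scatter. For compound 3 the expected value is 2500 nM, with an estimated range from 600 nM to 10000 nM.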

Compound 3, concentration for 50% growth inhibition: > 100000 nM
Compound 3: only a limit was reported; the forecaster's own chance of this, stated with the estimate: 15%; middle value at least 40-fold (1.60 log units) away from the limit.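

In this assay, within the data shown here, pyrrolidin-3-yl in place of 4-(trifluoromethyl)phenyl on a carbonyl carbon gives an at least 100-fold higher number from compound 1 to compound 3 (2.00 log units; beyond the scatter), a large step and the first comparison here of two compounds that differ in one place. Compound 3 stands at a limit of the assay and not at a number: the limit of > 100000 nM in this assay, at which 1 of the 3 values shown sits. With the rest of the core of compound 1 held constant, growth inhibition in this assay thus proves highly sensitive to the group at this position, which compound 1 and compound 2, differing in several places at once, could not show.

Going by these compounds, it remains open whether the step follows from losing the trifluoromethyl, losing the aromatic ring, or gaining the ring nitrogen with its hydrogen. An unsubstituted phenyl or a cyclopentyl group on this carbonyl carbon would help to separate these changes.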